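A few compounds are considered here, and "the series" means these few. Any claim that something is new, unique, unknown or untested is made for them only; others in the source may bear on it.

Series notes. Compound 1 `CC1CCN(C2CCN(S(=O)(=O)c3cccc(-c4ccccc4C(F)(F)F)c3)CC2)CC1`, compound 2 `CC1CCN(C2CCN(S(=O)(=O)c3ccc(C(C)(C)C)cc3)CC2)CC1` and compound 3 `CCc1ccc(S(=O)(=O)N2CCC(N3CCC(C)CC3)CC2)cc1` share one core and differ only in the group carried on the sulfonyl sulfur. In an ADME assay on HCT-116 cells (Homo sapiens) for cytotoxicity, read by CellTiter-Glo, with a stated time of 72 h (a higher number here means a weaker inhibitor, a lower number a stronger inhibitor), compound 1 gives > 5000 nM, which is a limit of the assay and not a number. Compound 2 likewise reaches only the limit > 5000 nM in this assay. Compound 3 also stops at the limit > 5000 nM in this assay. Among the compounds with values here, the single one-point step, a step that the two limits leave unreadable from compound 2 to compound 3, therefore cannot be read, since both of its ends sit at the limit of > 5000 nM in this assay, at which 3 of the 3 values shown sit. Compound 3 thus stands at the limit together with the other two, and no ordering among the three is possible.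

Compound 4 `CC1CCN(C2CCN(S(=O)(=O)c3cccnc3Cl)CC2)CC1` is not yet measured. It differs from compound 3 by 2-chloropyridin-3-yl in place of 4-ethylphenyl on a sulfonyl sulfur. Within the data shown here, no measured step touches this change, and the only step in hand is unreadable. The expectation for compound 4 in this assay is that it again reaches only the limit, so the step that the limit leaves unreadable from compound 3 to compound 4 is expected to be nothing readable. Compound 4 is estimated at 8000 nM, within 3000 nM to 30000 nM.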

Compound 4, half-maximal inhibitory concentration: > 10000 nM
Compound 4: only a limit was reported (the forecaster's own chance of this, stated with the estimate: 85%); middle value at least 1.2-fold (0.09 log units) from the limit.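

In this assay the values of compound 3 and compound 4 are both limits and not numbers, and no new step can be read between them. The compounds shown leave open whether any group on the sulfonyl sulfur gives a measurable half-maximal inhibitory concentration, and how these groups rank.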